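The source may hold more compounds than are shown below. What is called first, only, known or untested is meant among the compounds shown, and "the series" means these compounds.

Compound 1 `Cc1cc(Nc2cc(-c3ccccc3)[nH]n2)n2nc(SCc3ccc(F)cc3)nc2n1`, compound 2 `C#CCSc1nc2nc(C)cc(Nc3cc(-c4ccccc4)[nH]n3)n2n1` and compound 3 `C=CCSc1nc2nc(C)cc(Nc3cc(-c4ccccc4)[nH]n3)n2n1` share one core and differ only in the chain on sulfur. In an ADME assay on GES1 cells (Homo sapiens) for inhibition, read by MTT assay, with a stated time of 72 h (on this read-out higher numbers stand for weaker inhibition and lower numbers for stronger inhibition), compound 1 gives 35500 nM and compound 2 gives 45700 nM. Compound 3 is known only as a limit of the assay, > 50000 nM.

Compound 4 `Cc1cc(Nc2cc(-c3ccccc3)[nH]n2)n2ncnc2n1` has hydrogen in place of allylsulfanyl on an aromatic carbon, so the whole chain and its sulfur are gone: hydrogen in place of allylsulfanyl on an aromatic carbon. The measured steps bear on this only in part, as each alters the end of the chain and none removes it. They are a 1.3-fold higher number from compound 1 to compound 2 (0.11 log units; within the scatter), an at least 1.4-fold higher number from compound 1 to compound 3 (0.14 log units; that floor lies within the scatter) and an at least 1.0-fold higher number from compound 2 to compound 3 (0.03 log units; that floor lies within the scatter). Going by the values given here, none of these goes beyond the scatter, and the data hold no direct example of losing the chain. No step beyond the scatter is therefore expected in this assay, and the read-out may again reach the limit. The estimated change is a number no higher from compound 3 to compound 4 (the limit leaves the size open). The expected value for compound 4 is 50000 nM, within an estimated range from 25000 nM to 100000 nM.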

Compound 4, half-maximal inhibitory concentration: > 50000 nM
Compound 4: a limit, no number; the forecaster's own chance of this, stated with the estimate: 50%; the middle value lies on the limit itself.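

In this assay compound 4 gives > 50000 nM, which is a limit of the assay. Going by these compounds alone, with hydrogen on this aromatic carbon, so that the whole chain and its sulfur are gone, the read-out gives an at least 1.0-fold higher number from compound 2 to compound 4 (0.03 log units; that floor lies within the scatter) and an at least 1.4-fold higher number from compound 1 to compound 4 (0.14 log units; that floor lies within the scatter), so the earlier compounds' changes at the end of the chain now extend to complete loss of the chain without any step beyond the scatter. The step from compound 3 to compound 4 cannot be read, because both values are limits: the limit of > 50000 nM in this assay, at which 2 of the 4 values shown sit.

The compounds shown leave open whether an amine or a carboxylic acid on this aromatic carbon would shift the read-out beyond the scatter. They also leave open the actual values of compound 3 and compound 4.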